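Lengthening the amino side chain of compound 3

This account rests on a few compounds, and the source may have more. Where it says the series, first, only, none or still open, it means among the compounds named here.

In a functional assay on PC-3 cells (Homo sapiens) for antiproliferative activity, read by WST assay, with a stated time of 3 days (a higher number here means a weaker inhibitor, a lower number a stronger inhibitor), compound 3 (`CCCN(CCC)CCCCOc1c(-c2cc(OC)c(OC)c(OC)c2)oc2ccccc2c1=O`) gives 11600 nM and holds the lower of the two actual numbers in this small series. Among the measured compounds shown here, compound 1 (`CCCCCCOc1c(-c2cc(OC)c(OC)c(OC)c2)oc2ccccc2c1=O`) gives 29200 nM as the only other number. Compound 2 (`CCCCCCCOc1c(-c2cc(OC)c(OC)c(OC)c2)oc2ccccc2c1=O`) gives > 50000 nM as a limit of the assay and not a number.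

For the measured compounds named here, compound 4 (`CCCCCN(CCCCC)CCCCCOc1c(-c2cc(OC)c(OC)c(OC)c2)oc2ccccc2c1=O`) is still unmeasured and carries (dipentylamino)methyl in place of dipropylamino on a saturated chain carbon, four bonds along the chain from an oxygen on an aromatic ring as its single change.

Placing dipropylamino on the chain gave a 2.5-fold lower number from compound 1 to compound 3 (0.40 log units; beyond the scatter) and also an at least 4.3-fold lower number from compound 2 to compound 3 (0.63 log units; beyond the scatter) as the steps that bear most closely on this change. Lengthening a chain by a methyl gave an at least 1.7-fold higher number from compound 1 to compound 2 (0.23 log units; that floor lies within the scatter) but concerns a chain without an amino group. Going by the values given here, no measured step alters the chains on an amino group, so none sizes this change directly.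

Compound 4 keeps an amino group like compound 3 at 11600 nM so no step beyond the scatter is expected, with wide uncertainty in both directions. The expected step is a 1.3-fold lower number from compound 3 to compound 4 (0.11 log units; within the scatter) on this reasoning. Compound 4 is estimated at 9000 nM with an expected range from 3000 nM to 30000 nM in this assay when it is measured.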

Compound 4, half-maximal inhibitory concentration: 9600 nM
Compound 4: the middle estimate sits 1.1-fold (0.03 log units) below what was measured; measured number inside the range.
By their numbers in this assay, from the lowest: compounds 4 and 3 (each within the scatter of the next); then compound 1. At a limit, above all of these: compound 2.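

Changing dipropylamino to (dipentylamino)methyl on a saturated chain carbon, four bonds along the chain from an oxygen on an aromatic ring, is the first change shown within the amino-bearing chains, and in this assay it gives a 1.2-fold lower number from compound 3 to compound 4 (0.08 log units; within the scatter). The much larger amino chain therefore leaves compound 3 and compound 4 within the scatter of each other, so this position accepts the change with no measurable penalty or gain. The advantage of an amino-bearing chain over the plain chains also persists with the larger group, as shown by a 3.0-fold lower number from compound 1 to compound 4 (0.48 log units; beyond the scatter) and by an at least 5.2-fold lower number from compound 2 to compound 4 (0.71 log units; beyond the scatter), and neither amino-bearing compound goes against this within the four compounds. The second of these steps is only a floor, since compound 2 stands at a limit of the assay and not at a number: the limit of > 50000 nM in this assay, at which 1 of the 4 values shown sits.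

Compound 4 lengthens the chain to the nitrogen and the chains on the nitrogen together, so the two changes cannot be told apart here. As far as these compounds go, whether a smaller dimethylamino group or a ring amine such as piperidine would hold the same level remains open.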